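Fluoro-aniline thienolactam amides: side-chain ring swap

This account rests on a few compounds, and the source may have more. Where it says the series, first, only, none or still open, it means among the compounds named here.

Measured compounds:
compound 1 `CC1(C)CNC(=O)c2sc(Nc3ccc(I)cc3F)c(C(=O)NC[C@H]3CCCN3)c2C1` — 120 nM
compound 2 `CC1(C)CNC(=O)c2sc(Nc3ccc(I)cc3Cl)c(C(=O)NCC[C@@H](O)CO)c2C1` — 12100 nM
compound 3 `CC(C)(N)CNC(=O)c1c(Nc2ccc(I)cc2Cl)sc2c1CC(C)(C)CNC2=O` — 113 nM

In a functional assay on HT-29 cells (Homo sapiens) for antiproliferative activity (on this read-out lower numbers stand for stronger inhibition and higher numbers for weaker inhibition), compound 1 stands second highest of the three numbers, close to compound 3 and far from compound 2. Going by the values given here, the only one-place step, a 110-fold lower number from compound 2 to compound 3 (2.03 log units; beyond the scatter), concerns a different part of the side chain and bears only loosely on the present change.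

Compound 4 `CC1(C)CNC(=O)c2sc(Nc3ccc(I)cc3F)c(C(=O)N[C@@H]3CCCNC3)c2C1` differs from compound 1 by piperidin-3-yl in place of (pyrrolidin-2-yl)methyl on an amide-type nitrogen. Among the compounds with values here, no measured step covers this rearrangement; the pair compound 1 and compound 3 shows only that two amine-bearing side chains give similar numbers in this assay. Compound 4 is therefore expected to stay near compound 1, with a step of a 1.3-fold higher number from compound 1 to compound 4 (0.10 log units; within the scatter), giving an estimate of 150 nM within 50 nM to 500 nM.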

Compound 4, half-maximal inhibitory concentration: 91 nM
The estimate for compound 4 lay 1.6-fold (0.22 log units) above the measured number, and the stated range covers the measured number.
By their numbers in this assay, from the lowest: compounds 4, 3 and 1 (each within the scatter of the next); then compound 2.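

In this assay, moving from (pyrrolidin-2-yl)methyl to piperidin-3-yl on the amide-type nitrogen gives a 1.3-fold lower number from compound 1 to compound 4 (0.12 log units; within the scatter). With the same count of heavy atoms, this position therefore accepts a six-membered ring bound directly to that nitrogen as well as a five-membered ring bound through a methyl link, at least on the fluoro-aniline compounds shown. No available evidence accounts for this result.

As far as these compounds go, whether the ring nitrogen matters stays open, since cyclohexyl, which has carbon in its place, lies outside these compounds. So does the outcome with piperidin-4-yl, where the ring is attached at a different carbon.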